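Working notes on chain variation at the aromatic nitrogen

The source may report more compounds than this note shows. Statements on the series, on what has been measured and on what is new or still open speak of the compounds shown alone.

Measured compounds in a functional assay on BT-474 cells (Homo sapiens) for inhibition, read by fluorescence, with a stated time of 72 h; on this read-out lower numbers stand for stronger inhibition of growth and higher numbers for weaker inhibition of growth:
Compound 1, `CC(C)CCn1cnc2c(Nc3ccc(Cl)cc3)nc(N[C@H]3CC[C@H](N)CC3)nc21`, gives 5100 nM.
Compound 2, `CCCCCCn1cnc2c(Nc3cccc(Cl)c3)nc(N[C@H]3CC[C@H](N)CC3)nc21`, gives 5100 nM.
Compound 3, `COc1ccc(Cn2cnc3c(Nc4cccc(Cl)c4)nc(N[C@H]4CC[C@H](N)CC4)nc32)cc1`, gives 8200 nM.

Compound 3 carries the highest of the three numbers, yet both of its gaps, to compound 1 and to compound 2, fall within the scatter, so the three values cannot be ordered. Among the measured compounds shown here, the one step in a single place is a 1.6-fold higher number from compound 2 to compound 3 (0.21 log units; within the scatter).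

Compound 4, `CC(C)CCn1cnc2c(Nc3cccc(Cl)c3)nc(N[C@H]3CC[C@H](N)CC3)nc21`, is the next to be measured. Its difference from compound 3 is isobutyl in place of 4-methoxyphenyl on a saturated chain carbon bound to an aromatic nitrogen. The step from compound 2 to compound 3 bears directly on this place and was within the scatter. Compound 1 differs from compound 3 in a second place as well, and its value sits within the scatter of compound 3. For the measured compounds named here, no step observed here exceeds the scatter, so no change beyond the scatter is expected in this assay in either direction.

Compound 4 is expected to give 5000 nM, in the range 2500 nM to 10000 nM, which means an expected step of a 1.6-fold lower number from compound 3 to compound 4 (0.21 log units; within the scatter).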

Compound 4, concentration for 50% growth inhibition: 3800 nM
Beside the measured number, compound 4's estimate is 1.3-fold (0.12 log units) above it; low and high end bracket the measured number.
By their numbers in this assay, from the lowest: compounds 4, 1, 2 and 3 (each within the scatter of the next, the first and the last beyond it).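

In this assay, among the compounds shown here, the exchange of 4-methoxyphenyl for isobutyl gives a 2.2-fold lower number from compound 3 to compound 4 (0.33 log units; beyond the scatter) and so is the first step to pass the scatter, if only modestly. The other two new steps, a 1.3-fold lower number from compound 2 to compound 4 (0.13 log units; within the scatter) for isopropyl in place of butyl on the chain and a 1.3-fold lower number from compound 1 to compound 4 (0.13 log units; within the scatter) for 3-chlorophenyl in place of 4-chlorophenyl on a nitrogen on an aromatic ring, both stay within the scatter and so separate neither pair. For the compounds shown here, no evidence at hand accounts for the one step that passes the scatter.

The compounds shown leave open whether a plain benzyl group at this place would read like 4-methoxybenzyl or like isopentyl. They also leave open how an amine, a carboxylic acid or a longer chain would read at the same place.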